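Moving a Hydroxyl Group on a Shared Core

This account rests on a few compounds, and the source may have more. Where it says the series, first, only, none or still open, it means among the compounds named here.

Compound 1, `Oc1cccc(-c2cc(-c3cccc(F)c3)cc(-c3ccccc3O)n2)c1`: > 50000 nM
Compound 2, `Oc1ccccc1-c1cc(-c2ccccc2C(F)(F)F)cc(-c2ccccc2O)n1`: 3970 nM

Of the compounds shown here, two have been measured in a functional assay on HCT-15 cells (Homo sapiens) for inhibition; on this read-out higher numbers stand for weaker inhibition and lower numbers for stronger inhibition. Compound 1 returns only a limit, > 50000 nM, not a number. Compound 2 gives 3970 nM. Going by the values given here, compound 2 therefore holds the only numeric value in this set, and the other result is a limit: the limit of > 50000 nM in this assay, at which 1 of the 2 values shown sits.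

Compound 3, `Oc1cccc(-c2cc(-c3ccccc3C(F)(F)F)cc(-c3ccccc3O)n2)c1`, has not yet been measured. It is built from the same atoms as compound 2, joined differently: 3-hydroxyphenyl in place of 2-hydroxyphenyl on an aromatic carbon. Compound 1 also carries a 3-hydroxyphenyl group, but it differs from compound 3 in a further position as well, so its limit cannot be laid to the hydroxyl shift alone. Among the compounds with values here, no step between measured compounds is available to gauge this change, and the estimate rests on the single number of compound 2 and the limit of compound 1.

The expected step is a 3.8-fold higher number from compound 2 to compound 3 (0.58 log units; beyond the scatter), a weakening of inhibition beyond the scatter. Compound 3 is accordingly estimated at 15000 nM, with a range from 4000 nM to 50000 nM.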

Compound 3, half-maximal inhibitory concentration: 9010 nM
Beside the measured number, compound 3's estimate is 1.7-fold (0.22 log units) above it, and the stated range covers the measured number.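

Going by these compounds alone, compound 3 gives the first direct reading of the hydroxyl shift on the shared core: in this assay, 3-hydroxyphenyl in place of 2-hydroxyphenyl, on the aromatic carbon next to the ring nitrogen, gives a 2.3-fold higher number from compound 2 to compound 3 (0.36 log units; beyond the scatter). The shift therefore weakens inhibition only modestly and does not by itself take compound 3 to the limit of compound 1, while the other group on the core also counts: with 3-hydroxyphenyl held in place, 2-(trifluoromethyl)phenyl in place of 3-fluorophenyl gives an at least 5.5-fold lower number from compound 1 to compound 3 (0.74 log units; beyond the scatter). That second step is only a bound and not an exact size, because compound 1 returns a limit and not a number: the limit of > 50000 nM in this assay, at which 1 of the 3 values shown sits.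

The compounds shown leave open whether this position accepts groups other than a hydroxyphenyl, such as a methoxyphenyl or an aminophenyl group, and how a 4-hydroxyphenyl group would compare. They also leave open whether the hydroxyl shift has the same size when 3-fluorophenyl stands in place of 2-(trifluoromethyl)phenyl.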